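The source may report more compounds than this note shows. Statements on the series, on what has been measured and on what is new or still open speak of the compounds shown alone.

Measured so far:
compound 1, `O=C(N/N=C/c1ccc(/C=C/C(=O)c2ccc(Cl)cc2Cl)cc1)c1ccncc1`, 83.8%
compound 2, `N=C(N)N/N=C/c1ccc(/C=C/C(=O)c2ccc(F)cc2)cc1`, 90.7%

In a functional assay on the whole organism (Ear) for inhibition, with Mus musculus as the target, with a stated time of 30 min, at a dose of 100 mg/kg by the intraperitoneal route (a higher number here means more inhibition at the dose given (going by the name of the read-out), a lower number less inhibition), compound 2 gives 90.7%, and compound 1 gives 83.8%; the two values lie within the usual scatter of each other, so neither can be placed above the other. Compound 3, `N=C(N)N/N=C/c1ccc(/C=C/C(=O)c2ccc(Cl)cc2Cl)cc1`, is not yet measured. It is compound 2 with 2,4-dichlorophenyl in place of 4-fluorophenyl on a carbonyl carbon. Compound 1, at 83.8%, already carries 2,4-dichlorophenyl on its carbonyl carbon and sits close to compound 2, so no step beyond the scatter is expected in this assay. The expected step, a number 3.7 percentage points lower from compound 2 to compound 3 (within the scatter), stays within that scatter. Compound 3 is estimated at 87%, between 72% and 97%.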

Compound 3, a percentage reported as inhibition, in the whole organism at one dose (the size of the read-out at that dose, not a potency): 92.5%
Compound 3: the middle estimate sits 5.5 percentage points below what was measured, within the range that was stated.
By their numbers in this assay, from the lowest: compounds 1, 2 and 3 (each within the scatter of the next).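

In this assay, 2,4-dichlorophenyl in place of 4-fluorophenyl on the carbonyl carbon gives a number 1.8 percentage points higher from compound 2 to compound 3 (within the scatter) and so stays inside the usual scatter, which means this position accepts either ring at this dose. On the amine nitrogen, a group of 3 heavy atoms in place of a group of 8 heavy atoms gives a number 8.7 percentage points higher from compound 1 to compound 3 (within the scatter) and also stays inside the scatter. Nothing measured here explains these results. Going by these compounds, whether an unsubstituted phenyl or a 4-methoxyphenyl on the carbonyl carbon would fall in the same range remains open, as does the outcome at a lower dose.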